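The source may hold more compounds than are shown below. What is called first, only, known or untested is meant among the compounds shown, and "the series" means these compounds.

Working notes on the series, read in an ADME assay on H9c2 cells (Rattus norvegicus) for cytotoxicity; on this read-out higher numbers stand for weaker inhibition and lower numbers for stronger inhibition. Compound 1 (`CC(C)C(=O)Nc1nc2ccc(Cl)cc2s1`) gives > 50000 nM, which is a limit and not a number. Compound 2 (`CC(C)(C)C(=O)Nc1nc2ccc(Cl)cc2s1`) gives > 50000 nM, again a limit. Compound 3 (`O=C(Nc1nc2ccc(Cl)cc2s1)C1CCOC1`) gives > 50000 nM, also a limit. Going by the values given here, compound 3 therefore has no numerical position in the set, and the whole series so far is summed up as the limit of > 50000 nM in this assay, at which 3 of the 3 values shown sit.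

Compound 4 (`O=C(CCO)Nc1nc2ccc(Cl)cc2s1`) carries 2-hydroxyethyl in place of oxolan-3-yl on a carbonyl carbon. The nearest measured changes at that carbonyl carbon are a step that the two limits leave unreadable from compound 1 to compound 3 and a step that the two limits leave unreadable from compound 2 to compound 3, and a step that the two limits leave unreadable from compound 1 to compound 2 concerns the same group. All three have limits at both ends, so none has a readable size and none gives a direction.

The expectation rests on compound 3 and its limit of > 50000 nM. No shift beyond the scatter is expected in this assay, and the expected change is a step that the limit leaves unreadable from compound 3 to compound 4. For compound 4 the estimated value is 60000 nM, with an expected range from 25000 nM to 150000 nM. A report as a limit is the likely outcome.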

Compound 4, half-maximal inhibitory concentration: > 50000 nM
Compound 4: no number, only a limit (the forecaster's own chance of this, stated with the estimate: 85%); the middle value lies beyond the limit too.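

Compound 4 joins compounds 1, 2 and 3 as a limit, so no new step among these four compounds can be read in this assay: the limit of > 50000 nM in this assay, at which 4 of the 4 values shown sit.

The compounds shown leave open whether any group on this carbonyl carbon shifts the read-out in this assay, and in which direction and by how much.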